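Methoxy on the anilino ring: what to expect

A few compounds are considered here, and "the series" means these few. Any claim that something is new, unique, unknown or untested is made for them only; others in the source may bear on it.

compound 1 `Cc1nc(SCC(=O)Nc2nc(-c3ccc(Cl)cc3)cs2)n(Nc2ccccc2)c1C` — 34600 nM
compound 2 `Cc1ccc(Nn2c(SCC(=O)Nc3nc(-c4ccccc4)cs3)nc(C)c2C)cc1` — > 100000 nM

Of the compounds shown here, two sharing one core have been tested in a functional assay on T47D cells (Homo sapiens) for antiproliferative activity, read by sulforhodamine B assay, with a stated time of 48 h; a lower number here means that less compound is tolerated, a higher number that more compound is tolerated. Going by the values given here, compound 1 gives 34600 nM, the only plain number among the two. Compound 2 reaches only (the limit of > 100000 nM in this assay, at which 1 of the 2 values shown sits), which is a limit of the assay rather than a number. Compound 3 `COc1ccc(Nn2c(SCC(=O)Nc3nc(-c4ccc(Cl)cc4)cs3)nc(C)c2C)cc1` is not yet measured; it differs from compound 1 by methoxy in place of hydrogen on an aromatic carbon. Among the compounds with values here, with no measured pair showing this kind of change, the step from compound 1 is expected to be a 1.3-fold higher number from compound 1 to compound 3 (0.11 log units; within the scatter), not clearly beyond the scatter in either direction. Compound 3 is therefore estimated at 45000 nM, within 15000 nM to 120000 nM.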

Compound 3, concentration lethal to 50% of the cells: > 100000 nM
Compound 3: a limit, no number (the forecaster's own chance of this, stated with the estimate: 30%); at least 2.2-fold (0.34 log units) between middle value and limit.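

In this assay, methoxy in place of hydrogen on this aromatic carbon, para to a large group, gives an at least 2.8-fold higher number from compound 1 to compound 3 (0.46 log units; beyond the scatter). Going by these compounds alone, this is the first measured sign that the anilino ring of compound 1 does not accept every change at this position without a shift in the number. The full size of the step stays unknown, as compound 3 gives a limit and not a number: the limit of > 100000 nM in this assay, at which 2 of the 3 values shown sit.

Still open, on these data alone, is whether fluorine or an amine on this same carbon would lower the number, leave it in place or raise it as methoxy does.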